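A longer alkyl arm on compound 2

The source may hold more compounds than are shown below. What is called first, only, known or untested is meant among the compounds shown, and "the series" means these compounds.

For the measured compounds named here, compound 2 `CC/N=C(/NC#N)NCCCn1nc(-c2ccccc2)ccc1=O` is the only one of three measured compounds that gives a number in a functional assay on the whole organism (stomach) with Rattus norvegicus as the target; a lower number here means that less compound is needed, a higher number that more compound is needed for the effect: compound 2 gives 78.3 mg/kg. Compound 1 `C/N=C(/NC#N)NCCCCCCn1nc(-c2ccccc2)ccc1=O` reaches only a limit of this assay, > 100 mg/kg. Compound 3 `CC/N=C(/NC#N)NCCCCCCn1nc(-c2ccccc2)ccc1=O` likewise reaches only a limit, > 100 mg/kg. Compound 3 differs from compound 1 by methyl in place of hydrogen on a saturated chain carbon bound to a double-bonded nitrogen, and the step that the two limits leave unreadable from compound 1 to compound 3 cannot be sized because of the limit of > 100 mg/kg in this assay, at which 2 of the 3 values shown sit. The difference between the cores of compound 2 and compound 1 is not broken down here. Compound 4 `CCC/N=C(/NC#N)NCCCn1nc(-c2ccccc2)ccc1=O` differs from compound 2 by methyl in place of hydrogen on a saturated chain carbon, two bonds along the chain from a double-bonded nitrogen, the same kind of change as from compound 1 to compound 3, though here the place is two bonds along the chain from a double-bonded nitrogen rather than on a saturated chain carbon bound to a double-bonded nitrogen. With the earlier step unreadable, the expected step is a 1.0-fold higher number from compound 2 to compound 4 (0.01 log units; within the scatter). Compound 4 is therefore estimated at 80 mg/kg, between 30 mg/kg and 200 mg/kg.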

Compound 4, dose for half-maximal effect: 100 mg/kg
Beside the measured number, compound 4's estimate is 1.3-fold (0.10 log units) below it; the measured number falls inside the stated range.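

In this assay, the change from ethyl to propyl on the core of compound 2 gives a 1.3-fold higher number from compound 2 to compound 4 (0.11 log units; within the scatter), so on this core the two numbers cannot be told apart. One readable step on one core sets no rule for the series. It does not show whether the change carries over to another core, because the comparable step on the core of compound 1 cannot be read: the limit of > 100 mg/kg in this assay, at which 2 of the 4 values shown sit.

Still open, on these data alone, is whether butyl or a longer chain in place of the propyl group would give a step beyond the usual scatter. An amine or a carboxylic acid in that place also remains untested among the compounds shown here.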